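This account rests on a few compounds, and the source may have more. Where it says the series, first, only, none or still open, it means among the compounds named here.

Measured compounds:
Compound 1, `CC(C)=CCC[C@@](C)(/C=C/c1ccccc1)/C=C/c1ccc(O)cc1`: > 52000 nM
Compound 2, `CC(C)=CCC[C@](C)(/C=C/c1ccc(O)cc1)/C=C/c1cccc(F)c1`: > 52000 nM
Compound 3, `C=C[C@@](C)(/C=C/c1ccc(-c2ccccc2)cc1)CCC=C(C)C`: > 52000 nM

The three compounds were tested in a functional assay on HepG2 cells (Homo sapiens) for cytotoxicity, with a stated time of 72 h; on this read-out lower numbers stand for an effect already at smaller amounts and higher numbers for an effect only at larger amounts of compound. For compound 1 the value given is a limit of the assay and not a number. For compound 2 the value is likewise only a limit. For compound 3 too the result is a limit rather than a number. Compound 2 differs from compound 1 by fluoro in place of hydrogen on an aromatic carbon. The step that the two limits leave unreadable from compound 1 to compound 2 cannot be read in size because of the limit of > 52000 nM in this assay, at which 3 of the 3 values shown sit.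

The difference between the core of compound 3 and the core of compound 1 is not broken down here. Compound 4, `C=C[C@@](C)(/C=C/c1ccc(-c2ccc(F)cc2)cc1)CCC=C(C)C`, is not yet measured in this assay; it differs from compound 3 by fluoro in place of hydrogen on an aromatic carbon. Among the measured compounds shown here, this is the same kind of change as the one from compound 1 to compound 2, not the same change: in compound 2 the fluoro sits meta to a large group, in compound 4 it sits para to a large group.

Since all three measured compounds reach only the limit, the step from compound 3 to compound 4 is expected to be about none, a number no higher from compound 3 to compound 4 (the limit leaves the size open), resting on the limit for compound 3 and on the unreadable step from compound 1 to compound 2. Compound 4 is therefore estimated at 52000 nM in this assay, with a high chance that again only a limit is reported.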

Compound 4, half-maximal effective concentration: > 52000 nM
Compound 4 was reported as a limit (the forecaster's own chance of this, stated with the estimate: 85%); the middle value sits exactly at the limit.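

No step can be read between compound 3 and compound 4 in this assay, because both results are limits and not numbers: the limit of > 52000 nM in this assay, at which 4 of the 4 values shown sit.

The compounds shown leave open whether fluoro in place of hydrogen on an aromatic carbon changes the read-out at all, and at what concentration any of the four compounds would show an effect.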